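Working notes: replacing the aryl group in a five-ring series

The source may report more compounds than this note shows. Statements on the series, on what has been measured and on what is new or still open speak of the compounds shown alone.

Measured so far in a functional assay on the whole organism (strain Wister albino) for inhibition, with Rattus norvegicus as the target, read by paw edema, with a stated time of 1 h, at a dose of 50 mg/kg by the intraperitoneal route; a higher number here means more inhibition at the dose given (going by the name of the read-out), a lower number less inhibition:
compound 1 `Cc1ccc([C@@H]2CN(C)[C@]3(C(=O)Nc4ccccc43)[C@]23Cc2ccccc2C3=O)cc1` gives 56.4%
compound 2 `CN1C[C@@H](c2ccc(Cl)cc2)[C@@]2(Cc3ccccc3C2=O)[C@@]12C(=O)Nc1ccccc12` gives 27.9%

Compound 2 stands lowest of the two numbers. Going by the values given here, its only neighbour is compound 1, and the step of a number 28.5 percentage points lower from compound 1 to compound 2 (beyond the scatter) is beyond the scatter, the sole change being chloro in place of methyl on an aromatic carbon.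

Compound 3 `CN1C[C@@H](c2ccco2)[C@@]2(Cc3ccccc3C2=O)[C@@]12C(=O)Nc1ccccc12` is not yet measured. It differs from compound 2 by furan-2-yl in place of 4-chlorophenyl on a saturated ring carbon. The group leaving is 4-chlorophenyl; the group entering is furan-2-yl, which sits on the same saturated ring carbon of the five-membered non-aromatic ring with one nitrogen.

Among the compounds with values here, only one measured step exists, and it alters a substituent on the aromatic ring rather than the ring itself, so it bears on this change only loosely. It does show that a single change at this position moved the number by a number 28.5 percentage points lower from compound 1 to compound 2 (beyond the scatter), so a shift of at least that size is plausible, though its direction cannot be read from the two values. The expected step is a number 12.1 percentage points higher from compound 2 to compound 3 (beyond the scatter), with either direction possible. Compound 3 is therefore estimated at 40%, in a range from 18% to 62%.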

Compound 3, a percentage reported as inhibition, in the whole organism at one dose (the size of the read-out at that dose, not a potency): 48.8%
Compound 3: the middle estimate sits 8.8 percentage points below what was measured; the range from low to high includes it.
By their numbers in this assay, from the lowest: compound 2; then compounds 3 and 1 (each within the scatter of the next).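

In (this assay) the aryl group on this saturated ring carbon can give way to a five-membered aromatic ring with one oxygen without the number falling to the level of compound 2: furan-2-yl in place of 4-chlorophenyl gives a clear gain (a number 20.9 percentage points higher from compound 2 to compound 3 (beyond the scatter)), while furan-2-yl in place of 4-methylphenyl gives a step that does not separate the two compounds (a number 7.6 percentage points lower from compound 1 to compound 3 (within the scatter)). A six-membered aromatic ring of carbon only is therefore not required at this position to reach a number of the size seen with compound 1, and among the three groups shown, only 4-chlorophenyl stands apart, beyond the scatter from both others. No data shown here bear on what lies behind these differences.

All three groups shown at this carbon are aromatic rings, so the effect of an aminomethyl group, a carboxylic acid or a plain butyl chain in the same place remains open. With a single dose and a single time shown, it also remains open whether compound 3 and compound 1 would stay indistinguishable under other conditions.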